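Trifluoromethyl for fluoro on the benzyl ring of compound 3

The compounds below may be only part of what the source reports. "The series", "measured", "known", "first", "only" and "open" are said of these compounds alone.

Measured so far:
compound 1, `Cc1cc(OCc2ccccc2)c2nc(C)c(C)n2c1`: 86%
compound 2, `CCCCc1nc2c(OCc3ccccc3)cccn2c1N`: 26%
compound 3, `Cc1nc2c(OCc3ccc(F)cc3)cccn2c1N`: 95%

Of the compounds shown here, three have been tested in a functional assay on the whole organism with Rattus norvegicus as the target, at a dose of 40 mg/kg by the intraperitoneal route; a higher number here means more inhibition at the dose given (going by the name of the read-out), a lower number less inhibition. Compound 3 gives 95%, the highest of the three numbers shown. Among the compounds with values here, compound 1 gives 86%, a number that lies within the scatter of the one for compound 3, so the two cannot be set in order. Within the data shown here, compound 2 gives 26%, a number far lower than that of compound 3 and beyond the scatter; no single-point step connects any of these three, so only the values themselves can be compared.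

Compound 4, `Cc1nc2c(OCc3ccc(C(F)(F)F)cc3)cccn2c1N`, has not been measured. It differs from compound 3 in one place: trifluoromethyl in place of fluoro on an aromatic carbon.

Among the measured compounds shown here, no measured pair shows what a change of this kind does in this assay. With compound 3 already near the top of the scale, the step is expected to be small, downward if anything, and not beyond the scatter: a number 7 percentage points lower from compound 3 to compound 4 (within the scatter). Compound 4 is estimated to give 88%, in the range 68% to 99%.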

Compound 4, a percentage reported as inhibition, in the whole organism at one dose (the size of the read-out at that dose, not a potency): 78%
Compound 4: the middle estimate sits 10 percentage points above what was measured, and the stated range covers the measured number.
By their numbers in this assay, from the lowest: compound 2; then compounds 4, 1 and 3 (each within the scatter of the next, the first and the last beyond it).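

In this assay, trifluoromethyl in place of fluoro on an aromatic carbon, para to a large group, gives a number 17 percentage points lower from compound 3 to compound 4 (beyond the scatter). Within the data shown here, this is the first step that changes a single place, and it shows that the number responds to the group at this carbon, although compound 4 still gives 78% with four heavy atoms there instead of one. Nothing at hand accounts for the size or direction of this step.

The compounds shown leave open how hydrogen, chlorine, a methoxy group or a nitrile at this carbon would compare with fluoro and trifluoromethyl. Also open, as far as these compounds go, is what an ethyl group or a longer chain in place of the methyl on the shared core would do with the fluoro group kept.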